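A few compounds are considered here, and "the series" means these few. Any claim that something is new, unique, unknown or untested is made for them only; others in the source may bear on it.

Compound 2 `N#C/C(=C\c1cc(O)c(O)c([N+](=O)[O-])c1)C(=O)N1CCOCC1` has been tested in a functional assay on BGC-823 cells (Homo sapiens) for antiproliferative activity, read by MTT assay (on this read-out lower numbers stand for stronger inhibition and higher numbers for weaker inhibition), where its value of > 100 ug/mL is a limit of the assay rather than a number. Compound 1 `N#C/C(=C\c1cc(O)c(O)c([N+](=O)[O-])c1)C(=O)N1CCCCC1` likewise reaches only a limit, > 100 ug/mL. The step that the two limits leave unreadable from compound 1 to compound 2 is therefore unreadable. Compound 3 `N#C/C(=C\c1cc(O)c(O)c([N+](=O)[O-])c1)C(N)=O` differs from compound 2 by amino in place of morpholin-4-yl on a carbonyl carbon. For the measured compounds named here, both measured values sit at the same limit (the limit of > 100 ug/mL in this assay, at which 2 of the 2 values shown sit), so no measured step bears on this new change and no direction can be taken from the data. The step that this estimate means is expected to be a number no higher from compound 2 to compound 3 (the limit leaves the size open). Compound 3 is estimated at 100 ug/mL, within a range from 30 ug/mL to 300 ug/mL.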

Compound 3, half-maximal inhibitory concentration: > 100 ug/mL
Compound 3 gave a limit, no number; the forecaster's own chance of this, stated with the estimate: 75%; the middle value lies on the limit itself.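

Compound 3 also gives only a limit in this assay, so the steps among compound 1, compound 2 and compound 3 cannot be read: the limit of > 100 ug/mL in this assay, at which 3 of the 3 values shown sit. On these data alone, whether piperidin-1-yl, morpholin-4-yl and amino on the carbonyl carbon differ at all in this assay stays open.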